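Swapping fluoro for bromo on the phenyl ring

This account rests on a few compounds, and the source may have more. Where it says the series, first, only, none or still open, it means among the compounds named here.

Compound 1 `COc1cc2c(Oc3ccc(NC(=O)c4nn(-c5ccccc5Br)c(=O)c5ccccc45)cc3F)ccnc2cc1OCCCN1CCCC1` gives 850 nM in a functional assay on HT-29 cells (Homo sapiens) for cytotoxicity, read by MTT assay, with a stated time of 72 h; on this read-out lower numbers stand for stronger inhibition and higher numbers for weaker inhibition.
Compound 2 `COc1cc2c(Oc3ccc(NC(=O)c4nn(-c5ccc(F)cc5)c(=O)c5ccccc45)cc3F)ccnc2cc1OCCCN1CCN(C)CC1` gives 320 nM in this assay.
Compound 3 `COc1cc2c(Oc3ccc(NC(=O)c4nn(-c5ccccc5F)c(=O)c5ccccc45)cc3F)ccnc2cc1OCCCN1CCN(C)CC1` gives 480 nM in this assay.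

Among these three numbers compound 3 holds the second highest. Its nearest neighbour is compound 2, and the gap between them is within the scatter; the farthest is compound 1, and that gap too is within the scatter, so nothing separates the three beyond what repeated measurement would give.

Compound 4 `COc1cc2c(Oc3ccc(NC(=O)c4nn(-c5ccccc5Br)c(=O)c5ccccc45)cc3F)ccnc2cc1OCCCN1CCN(C)CC1` differs from compound 3 in one place: bromo in place of fluoro on an aromatic carbon. Among the measured compounds shown here, only one measured step touches this phenyl ring, a 1.5-fold higher number from compound 2 to compound 3 (0.18 log units; within the scatter), and it moved the fluoro rather than exchanging it, with a result inside the scatter. Compound 1 carries the same bromo that enters here, but it also differs from compound 4 in the tail, so its value can only hint that a bromo at this position sits in the same range as the rest.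

On that basis the step of a 1.1-fold higher number from compound 3 to compound 4 (0.06 log units; within the scatter) is expected to be small, with no direction beyond the scatter. The estimate for compound 4 is 550 nM, with a range from 250 nM to 1200 nM.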

Compound 4, half-maximal inhibitory concentration: 1190 nM
Compound 4: the middle estimate sits 2.2-fold (0.34 log units) below what was measured; the range from low to high includes it.
By their numbers in this assay, from the lowest: compounds 2, 3, 1 and 4 (each within the scatter of the next, the first and the last beyond it).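

In this assay, among the compounds shown here, the 2-fluorophenyl to 2-bromophenyl change gives a 2.5-fold higher number from compound 3 to compound 4 (0.39 log units; beyond the scatter) and is the first step on this phenyl ring to fall outside the scatter, so the choice of bromo or fluoro on this aromatic carbon, ortho to a large group, does register in the read-out. The step of a 3.7-fold higher number from compound 2 to compound 4 (0.57 log units; beyond the scatter) points the same way when 2-bromophenyl replaces 4-fluorophenyl, whereas moving the fluoro alone gave only a 1.5-fold higher number from compound 2 to compound 3 (0.18 log units; within the scatter) and could not be told from repeated measurement. With the bromo in place, the tail shows no such separation: the step of a 1.4-fold higher number from compound 1 to compound 4 (0.15 log units; within the scatter) means that 4-methylpiperazin-1-yl and pyrrolidin-1-yl cannot be told apart in this pair.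

Nothing available here explains why bromo and fluoro differ at this position. As far as these compounds go, it also remains open where chloro, methyl or a plain hydrogen on the same aromatic carbon would fall, and so whether the numbers follow a trend across such groups or the bromo simply stands apart.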